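A few compounds are considered here, and "the series" means these few. Any claim that something is new, unique, unknown or untested is made for them only; others in the source may bear on it.

Compound 2, `Cc1cccc(/C(CCN2CCN(c3ccccn3)CC2)=N/O)c1`, gives 74% in a functional assay on HEK293 cells with D(4) dopamine receptor (Homo sapiens) as the target, read by FLIPR (on this read-out lower numbers stand for smaller maximal responses and higher numbers for larger maximal responses), the highest of the two numbers recorded, though its nearest neighbour, compound 1, `O/N=C(\CCN1CCN(c2ccccn2)CC1)c1ccccc1`, gives 70% in this assay, a value within the scatter of it. Among the measured compounds shown here, the one step measured so far, a number 4 percentage points higher from compound 1 to compound 2 (within the scatter), concerns the same aromatic carbon that is changed here and shows no effect beyond the scatter. The step from compound 2 to the unmeasured compound 3, `N#Cc1cccc(/C(CCN2CCN(c3ccccn3)CC2)=N/O)c1`, is cyano in place of methyl on an aromatic carbon. The measured step bears on it only in part, as it introduced the methyl that now leaves rather than a cyano. For the measured compounds named here, with the only relevant step being within the scatter, compound 3 is expected to show a step of a number 2 percentage points lower from compound 2 to compound 3 (within the scatter) in this assay, that is, no change beyond the scatter. Compound 3 is therefore estimated at 72% in this assay, within a range from 55% to 88%.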

Compound 3, largest response reached (reported as efficacy), in percent of the reference or control that the assay uses: 48%
Compound 3: the middle estimate sits 24 percentage points above what was measured, outside the stated range (below it).
By their numbers in this assay, from the lowest: compound 3; then compounds 1 and 2 (each within the scatter of the next).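

In this assay, this aromatic carbon proves sensitive to what it carries: methyl had left the response within the scatter, whereas cyano in place of methyl gives a number 26 percentage points lower from compound 2 to compound 3 (beyond the scatter). Cyano in place of hydrogen gives a number 22 percentage points lower from compound 1 to compound 3 (beyond the scatter), so the fall appears against both neighbours and does not depend on which one serves as the reference. Nothing shown gives a reason for this difference.

As far as these compounds go, whether the lower maximal response is particular to cyano remains open, since a methoxy group, an amine or a carboxylic acid on the same aromatic carbon would show how far other groups follow it. Also open, from the compounds shown here alone, is whether cyano would give a similar step on another carbon of this ring.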